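This account rests on a few compounds, and the source may have more. Where it says the series, first, only, none or still open, it means among the compounds named here.

Measured compounds:
- compound 1, `CCN(CC)c1ccc(NC(=O)c2c(-c3c(Cl)cccc3Cl)noc2CCOC)cc1`, 115 nM
- compound 2, `CCN(CC)c1ccc(NC(=O)c2c(-c3c(Cl)cccc3Cl)noc2CCC2OCCCO2)cc1`, 19 nM
- compound 3, `CCN(CC)c1ccc(NC(=O)c2c(-c3c(Cl)cccc3Cl)noc2CCC2CCCCO2)cc1`, 102 nM

All three share one core and differ only in the group carried on a saturated chain carbon, two bonds along the chain from an aromatic carbon. In a functional assay on CHO-K cells with growth hormone secretagogue receptor type 1 (Homo sapiens) as the target, read by FLIPR (a lower number here means a stronger inhibitor, a higher number a weaker inhibitor), compound 3 stands second highest of the three numbers: its nearest neighbour is compound 1, with a 1.1-fold lower number from compound 1 to compound 3 (0.05 log units; within the scatter), and its furthest is compound 2, with a 5.4-fold higher number from compound 2 to compound 3 (0.73 log units; beyond the scatter).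

Compound 4, `CCN(CC)c1ccc(NC(=O)c2c(-c3c(Cl)cccc3Cl)noc2CCC2CCCO2)cc1`, has not yet been measured. Its difference from compound 3 is oxolan-2-yl in place of oxan-2-yl on a saturated chain carbon, two bonds along the chain from an aromatic carbon.

For the measured compounds named here, two measured steps touch the same place. The exchange of methoxy for oxan-2-yl, a 1.1-fold lower number from compound 1 to compound 3 (0.05 log units; within the scatter), moved nothing beyond the scatter, whereas the exchange of the ring with two hetero atoms for the ring with one, a 5.4-fold higher number from compound 2 to compound 3 (0.73 log units; beyond the scatter), was a modest loss. Going by the values given here, neither step is a change of ring size alone, so no direct precedent for oxolan-2-yl exists. Because a 1.1-fold lower number from compound 1 to compound 3 (0.05 log units; within the scatter) lies within the scatter, the smaller one-oxygen ring of compound 4 is expected to stay near that level, with a 1.1-fold lower number from compound 3 to compound 4 (0.03 log units; within the scatter). Compound 4 is therefore estimated at 95 nM, within a range of 40 nM to 230 nM.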

Compound 4, half-maximal inhibitory concentration: 57 nM
Compound 4: the middle estimate sits 1.7-fold (0.22 log units) above what was measured; low and high end bracket the measured number.
By their numbers in this assay, from the lowest: compound 2; then compounds 4, 3 and 1 (each within the scatter of the next).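

In this assay, for the compounds shown here, this is the first step that changes only ring size on the saturated chain carbon: oxolan-2-yl in place of oxan-2-yl gives a 1.8-fold lower number from compound 3 to compound 4 (0.25 log units; within the scatter) and stays within the scatter, so the data cannot separate the five-membered ring from the six-membered one when each holds a single oxygen. Oxolan-2-yl in place of methoxy gives a 2.0-fold lower number from compound 1 to compound 4 (0.30 log units; within the scatter) and is also within the scatter, which places compounds 1, 3 and 4 together as one level, whether the group is an open chain or either ring with one oxygen. Against that level, the ring with two oxygens remains apart, as a 3.0-fold higher number from compound 2 to compound 4 (0.48 log units; beyond the scatter) lies beyond the scatter, and compound 2 now has the lowest number of the four, with its steps to all three others beyond the scatter.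

No measurement shown gives a reason for compound 2 standing apart. Still open, going by these compounds, is whether dioxolan-2-yl, a five-membered ring with two oxygens, would match compound 2, and how a ring amine such as piperidin-2-yl would compare with these oxygen rings at the same place.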